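The source may hold more compounds than are shown below. What is called first, only, known or untested is meant among the compounds shown, and "the series" means these compounds.

Measured in a functional assay on HCT-116 cells (Homo sapiens) for inhibition, read by MTT assay, with a stated time of 48 h; on this read-out lower numbers stand for stronger inhibition and higher numbers for weaker inhibition:
Compound 1 `COc1cc(-c2nnc(S)n2-c2ccc(N(C)C)cc2)cc(OC)c1OC`: > 60000 nM (a limit)
Compound 2 `COc1cc(-c2nnc(SCc3ccccc3)n2-c2ccc(N(C)C)cc2)cc(OC)c1OC`: 54000 nM
Compound 3 `COc1ccc(C(=O)CSc2nnc(-c3cc(OC)c(OC)c(OC)c3)n2-c2ccc(N(C)C)cc2)cc1O`: > 100000 nM (a limit)

Compound 3 gives only a limit, > 100000 nM, and the highest one shown. Compound 4 `COc1ccc(NC(=O)CSc2nnc(-c3cc(OC)c(OC)c(OC)c3)n2-c2ccc(N(C)C)cc2)cc1` changes one part of compound 3: (4-methoxyphenyl)amino in place of 3-hydroxy-4-methoxyphenyl on a carbonyl carbon. In words, (4-methoxyphenyl)amino replaces 3-hydroxy-4-methoxyphenyl on a carbonyl carbon.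

Two measured steps also change the group on sulfur: an at least 1.1-fold lower number from compound 1 to compound 2 (0.04 log units; that floor lies within the scatter), and an at least 1.8-fold higher number from compound 2 to compound 3 (0.26 log units; that floor lies within the scatter). Each gives only a floor within the scatter, so neither offers a firm size to carry over. For the measured compounds named here, compound 2 holds the only exact number, 54000 nM, so a modest move towards lower numbers is expected, landing near that level. The estimated change is an at least 2.0-fold lower number from compound 3 to compound 4 (0.30 log units; that floor lies within the scatter). For compound 4, the expected value is 50000 nM, within an estimated range of 10000 nM to 120000 nM.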

Compound 4, half-maximal inhibitory concentration: > 60000 nM
Compound 4: no number, only a limit (the forecaster's own chance of this, stated with the estimate: 40%); at least 1.2-fold (0.07 log units) between middle value and limit.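

In this assay, compound 4 gives > 60000 nM, which is a limit, so (4-methoxyphenyl)amino on the carbonyl carbon yields no exact number either. Placing (4-methoxyphenyl)carbamoyl instead of phenyl on the saturated chain carbon bound to a sulfur gives an at least 1.1-fold higher number from compound 2 to compound 4 (0.04 log units; that floor lies within the scatter), so this change shows no gain over compound 2. The steps to compound 4 from compound 1 and from compound 3 cannot be read.

From the compounds shown here alone, it remains open where compound 4's true value lies. Going by these compounds, it also remains open whether a carboxylic acid or an amine at this carbonyl position would give an exact number.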